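Benzyl for Phenyl on the Aryl Oxygen: Cytotoxicity Outlook

This account rests on a few compounds, and the source may have more. Where it says the series, first, only, none or still open, it means among the compounds named here.

Compound 1 `Cc1cccc(C2CC(c3ccc(Oc4ccccc4)cc3)=NN2c2ccc(S(N)(=O)=O)cc2)c1`: 81000 nM
Compound 2 `NS(=O)(=O)c1ccc(N2N=C(c3ccc(Oc4ccccc4)cc3)CC2c2ccc(Cl)cc2)cc1`: 88000 nM
Compound 3 `NS(=O)(=O)c1ccc(N2N=C(c3ccc(Oc4ccccc4)cc3)CC2c2ccc(F)cc2)cc1`: 25000 nM

Of the compounds shown here, three sharing one core have been measured in an ADME assay on Vero 76 cells (Chlorocebus sabaeus) for cytotoxicity, read by MTT assay, with a stated time of 96 h; on this read-out higher numbers stand for lower toxicity in this test and lower numbers for higher toxicity in this test. Among them compound 1 stands second highest of the three numbers; its nearest neighbour is compound 2, with a 1.1-fold higher number from compound 1 to compound 2 (0.04 log units; within the scatter), a change within the scatter, while compound 3 lies furthest, with a 3.2-fold lower number from compound 1 to compound 3 (0.51 log units; beyond the scatter). The step of a 3.5-fold lower number from compound 2 to compound 3 (0.55 log units; beyond the scatter) also exceeds the scatter.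

Compound 4 `Cc1cccc(C2CC(c3ccc(OCc4ccccc4)cc3)=NN2c2ccc(S(N)(=O)=O)cc2)c1` differs from compound 1 in one place: benzyl in place of phenyl on an oxygen on an aromatic ring. Every measured step alters the group on a saturated ring carbon, and none touches the oxygen on the aromatic ring. For the measured compounds named here, there is therefore no measured step that bears directly on this change; the modest steps seen so far concern a different part of the molecule. Without a comparable precedent, no step beyond the scatter is expected in this assay for compound 4, in either direction, and the range is set wide to reflect that.

The expected step of a 1.0-fold lower number from compound 1 to compound 4 (0.01 log units; within the scatter) is essentially flat. Compound 4 is estimated at 80000 nM, with a range from 30000 nM to 200000 nM.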

Compound 4, half-maximal cytotoxic concentration: 100000 nM
Beside the measured number, compound 4's estimate is 1.3-fold (0.10 log units) below it; measured number inside the range.
By their numbers in this assay, from the lowest: compound 3; then compounds 1, 2 and 4 (each within the scatter of the next).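

In this assay, for the compounds shown here, this is the first change at the oxygen on an aromatic ring, and benzyl in place of phenyl gives a 1.2-fold higher number from compound 1 to compound 4 (0.09 log units; within the scatter), so going from phenoxy to benzyloxy produces no step beyond the scatter. Every earlier step had altered the group on a saturated ring carbon, where 4-fluorophenyl in place of 3-methylphenyl gave a 3.2-fold lower number from compound 1 to compound 3 (0.51 log units; beyond the scatter); the oxygen position has so far shown no such movement, though this rests on a single pair of compounds. No measurement here offers an explanation for the flat result.

Going by these compounds, it remains open whether the number would also hold with a methyl or a longer chain such as phenethyl on that oxygen, or with a benzyl group carrying an amine or a carboxylic acid. The compounds shown also leave open whether benzyloxy combined with 4-fluorophenyl on the saturated ring carbon would give the lower number seen for compound 3 or a number closer to that of compound 4.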